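Removing a drawn configuration at the hydroxy analogue

This account rests on a few compounds, and the source may have more. Where it says the series, first, only, none or still open, it means among the compounds named here.

Measured so far:
- Compound 1, `Fc1ccc(-c2cn(C3CN4CCC3CC4)nn2)cc1`: 449 nM
- Compound 2, `Fc1ccc(-c2cn([C@@H]3CN4CCC3CC4)nn2)cc1`: 515 nM
- Compound 3, `Oc1ccc(-c2cn([C@@H]3CN4CCC3CC4)nn2)cc1`: 461 nM

All three were tested in an assay on HEK293 cells for displacement of a labelled ligand from Neuronal acetylcholine receptor; alpha4/beta2 (Homo sapiens), read by scintillation counting, with a stated time of 120 min; on this read-out lower numbers stand for stronger inhibition and higher numbers for weaker inhibition. Compound 3 gives 461 nM, the second highest of the three numbers; its gap to compound 1 and its gap to compound 2 both lie within the scatter, so none of the three can be called stronger or weaker than another.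

Compound 4, `Oc1ccc(-c2cn(C3CN4CCC3CC4)nn2)cc1`, has not yet been measured. It differs from compound 3 only in this: the two compounds have the same atoms and bonds; at least one stereo element is drawn with a configuration in one of them and without one in the other: 1 of 3 stereo elements differ; a stereocentre at a saturated ring carbon is drawn S in compound 3 and without a configuration in compound 4. Among the compounds with values here, the one measured step that bears on such a change is the one from compound 1 to compound 2, where the same stereocentre goes from undrawn to S, and it gave a 1.1-fold higher number from compound 1 to compound 2 (0.06 log units; within the scatter). Because of the fact that one of compounds 1 and 2 is drawn with a defined configuration and the other without, at the place where they differ, that pair is the direct counterpart of the present one, only in the reverse direction. A step of no more than the scatter, in no particular direction, is therefore expected for a 1.0-fold lower number from compound 3 to compound 4 (0.02 log units; within the scatter). Compound 4 is estimated at 440 nM, with a range from 220 nM to 900 nM.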

Compound 4, inhibition constant: 627 nM
For compound 4 the middle estimate is 1.4-fold (0.15 log units) below the measured one; low and high end bracket the measured number.
By their numbers in this assay, from the lowest: compounds 1, 3, 2 and 4 (each within the scatter of the next).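

Dropping the drawn configuration has now been read on a second aromatic substituent, hydroxy as well as fluoro, and it gives a 1.4-fold higher number from compound 3 to compound 4 (0.13 log units; within the scatter) in this assay. Putting hydroxy in place of fluoro, earlier read only with the S centre drawn, can now also be read with no configuration drawn, as a 1.4-fold higher number from compound 1 to compound 4 (0.15 log units; within the scatter), and the two readings agree: the same change on two cores in this assay, a 1.1-fold lower number (0.05 log units; within the scatter) from compound 2 to compound 3 and a 1.4-fold higher number (0.15 log units; within the scatter) from compound 1 to compound 4, 1.6-fold (0.19 log units) apart, within the scatter of two such steps Across these four compounds, neither change moves the number beyond the scatter, so neither the drawing of this stereocentre nor the swap at this aromatic carbon separates them.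

The compounds shown leave open what a centre drawn R would give, since every defined centre here is S. They also leave open whether a larger change at the aromatic carbon, such as a methoxy group or an amine, would stay within the scatter.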